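The compounds below may be only part of what the source reports. "The series", "measured", "known", "first", "only" and "open" are said of these compounds alone.

Values from a functional assay on Jurkat cells (Homo sapiens) for antiproliferative activity, read by MTT assay, with a stated time of 72 h (on this read-out lower numbers stand for stronger inhibition and higher numbers for weaker inhibition), follow
- compound 1 `COc1ccc(-c2c(C(=O)c3cc(OC)c(OC)c(OC)c3)sc3ccccc23)c(OC)c1` gives 4000 nM
- compound 2 `COc1ccc(OC)c(-c2c(C(=O)c3cc(OC)c(OC)c(OC)c3)sc3ccccc23)c1` gives > 10000 nM as a limit of the assay

Compound 2 has no number of its own (the limit of > 10000 nM in this assay, at which 1 of the 2 values shown sits). The change to compound 3 `COc1cc(C(=O)c2sc3ccccc3c2Nc2ccc(Cl)cc2)cc(OC)c1OC` puts (4-chlorophenyl)amino in place of 2,5-dimethoxyphenyl on an aromatic carbon. Among the measured compounds shown here, the one measured step (an at least 2.5-fold higher number from compound 1 to compound 2 (0.39 log units; beyond the scatter)) only exchanges 2,4-dimethoxyphenyl for 2,5-dimethoxyphenyl, so it bears loosely on this change. For the measured compounds named here, compound 1 with 4000 nM is the only true number to lean on, so a modest step toward lower numbers is expected in this assay. Compound 3 may well stay at the limit. The expected step is estimated as an at least 2.5-fold lower number from compound 2 to compound 3 (0.39 log units; beyond the scatter) and no more than that. Compound 3 is estimated at 4000 nM (range 600 nM to 10000 nM).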

Compound 3, half-maximal inhibitory concentration: 1900 nM
Beside the measured number, compound 3's estimate is 2.1-fold (0.32 log units) above it, within the range that was stated.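

In this assay, this aromatic carbon of the five-membered aromatic ring with 1 sulfur tolerates a nitrogen-linked ring, with (4-chlorophenyl)amino giving an at least 5.2-fold lower number from compound 2 to compound 3 (0.72 log units; beyond the scatter). The same change made against 2,4-dimethoxyphenyl gives a 2.1-fold lower number from compound 1 to compound 3 (0.32 log units; beyond the scatter), so the gain is not confined to comparison with the weaker dimethoxyphenyl isomer. Compound 2 sits at a limit, so its step gives only a bound: the limit of > 10000 nM in this assay, at which 1 of the 3 values shown sits.

Going by these compounds, whether the gain belongs to the amino link or to the chlorine remains open. Plain phenylamino or (4-methoxyphenyl)amino at this position would separate the two.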